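Ethyl to 3-(trifluoromethyl)phenyl on the ring nitrogen: an expectation

A few compounds are considered here, and "the series" means these few. Any claim that something is new, unique, unknown or untested is made for them only; others in the source may bear on it.

Compound 1, `CN(C[C@H]1Cc2c(cccc2N2CCN(Cc3ccccn3)CC2)CN1)[C@H]1CCCc2cccnc21`, gives only a limit in a functional assay on CCRF-CEM cells for agonist activity at C-X-C chemokine receptor type 4 (Homo sapiens), read by calcium flux, with a stated time of 25 min; a lower number here means that less compound is needed, a higher number that more compound is needed for the effect: > 30000 nM.
Compound 2, `CN(C[C@H]1Cc2c(cccc2N2CCNCC2)CN1)[C@H]1CCCc2cccnc21`, gives a limit as well: > 30000 nM.
Compound 3, `CCN1CCN(c2cccc3c2C[C@H](CN(C)[C@H]2CCCc4cccnc42)NC3)CC1`, gives a limit too: > 30000 nM.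

Compound 3 therefore stands exactly where the other two measured compounds stand, at the limit of > 30000 nM in this assay, at which 3 of the 3 values shown sit, and no number for it is known beyond that limit. Compound 4, `CN(C[C@H]1Cc2c(cccc2N2CCN(c3cccc(C(F)(F)F)c3)CC2)CN1)[C@H]1CCCc2cccnc21`, differs from compound 3 in one place: 3-(trifluoromethyl)phenyl in place of ethyl on an amine nitrogen in a ring. Within the data shown here, three measured steps touch this same ring nitrogen, a step that the two limits leave unreadable from compound 1 to compound 2, a step that the two limits leave unreadable from compound 1 to compound 3 and a step that the two limits leave unreadable from compound 2 to compound 3, and none of them has a readable size, as every compound involved sits at a limit. Nothing measured here points to a step beyond the scatter in either direction, and nothing rules one out. Compound 4 is therefore expected to give 30000 nM, with a range from 8000 nM to 100000 nM. The step this estimate means is expected to be a number no higher from compound 3 to compound 4 (the limit leaves the size open).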

Compound 4, half-maximal effective concentration: > 30000 nM
Compound 4: no number, only a limit (the forecaster's own chance of this, stated with the estimate: 75%); the middle value lies on the limit itself.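

Compound 4 gives only a limit in this assay: > 30000 nM. Its steps from compounds 1, 2 and 3 cannot be read, as all four compounds share one limit: the limit of > 30000 nM in this assay, at which 4 of the 4 values shown sit.

The compounds shown leave open how much of any of the four would be needed for the effect, and so whether the group on the ring nitrogen matters at all.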